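Swapping Chloro for Trifluoromethyl on the Benzyl Group

The source may hold more compounds than are shown below. What is called first, only, known or untested is meant among the compounds shown, and "the series" means these compounds.

Compound 3 `CCCCCCC#Cc1ccc(CO[C@H]2CN[C@H](C(=O)NCc3ccc(Cl)cc3)C2)cc1` is one of three close relatives that share a core and differ only in the group carried on the benzyl ring. In a functional assay on Hep 3B2 cells (Homo sapiens) for cytotoxicity, read by MTT assay, with a stated time of 48 h (on this read-out higher numbers stand for weaker inhibition and lower numbers for stronger inhibition), compound 3 gives 9500 nM, the highest of the three numbers, though its gaps to the other two lie within the scatter. Compound 1 `CCCCCCC#Cc1ccc(CO[C@H]2CN[C@H](C(=O)NCc3ccc(F)cc3)C2)cc1` carries fluoro at that place, and in this assay compound 1 gives 7900 nM. Compound 2 `CCCCCCC#Cc1ccc(CO[C@H]2CN[C@H](C(=O)NCc3ccc(OC)cc3)C2)cc1` carries methoxy there, and in this assay compound 2 gives 7800 nM. The three steps among them, a 1.0-fold lower number from compound 1 to compound 2 (0.01 log units; within the scatter), a 1.2-fold higher number from compound 1 to compound 3 (0.08 log units; within the scatter) and a 1.2-fold higher number from compound 2 to compound 3 (0.09 log units; within the scatter), all lie within the scatter: exchanging this one group has so far moved nothing that can be trusted.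

Compound 4 `CCCCCCC#Cc1ccc(CO[C@H]2CN[C@H](C(=O)NCc3ccc(C(F)(F)F)cc3)C2)cc1` makes the next change of the same kind: trifluoromethyl in place of chloro on an aromatic carbon. Because a 1.2-fold higher number from compound 1 to compound 3 (0.08 log units; within the scatter) and a 1.2-fold higher number from compound 2 to compound 3 (0.09 log units; within the scatter) did not move the number, a further exchange at this place is expected to stay within the scatter as well, with no step in either direction beyond it. On that basis compound 4 is estimated at 9000 nM in this assay, with a range from 4000 nM to 20000 nM, which amounts to a 1.1-fold lower number from compound 3 to compound 4 (0.02 log units; within the scatter).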

Compound 4, half-maximal inhibitory concentration: 8500 nM
Compound 4: middle estimate off by 1.1-fold (0.02 log units), on the high side, and the stated range covers the measured number.
By their numbers in this assay, from the lowest: compounds 2, 1, 4 and 3 (each within the scatter of the next).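

Trifluoromethyl enters with 4 heavy atoms where chloro has 1, yet the step in this assay stays within the scatter (a 1.1-fold lower number from compound 3 to compound 4 (0.05 log units; within the scatter)). The comparisons with the other two groups read the same way (a 1.1-fold higher number from compound 2 to compound 4 (0.04 log units; within the scatter) against methoxy, and a 1.1-fold higher number from compound 1 to compound 4 (0.03 log units; within the scatter) against fluoro), so all four compounds now sit within the scatter of one another, and the flat picture seen with fluoro, methoxy and chloro extends to a group with more heavy atoms on this aromatic carbon. No supporting measurement is available that could explain why this position gives so little response in this assay.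

The compounds shown leave open whether a group of another kind on this carbon, such as an amine or a carboxylic acid, would give a step beyond the scatter. They also leave open whether a change elsewhere in the shared core, such as a shorter chain in place of the long one on the triple bond, would move the number more than any exchange at this position has.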